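From quinolin-5-yl to 2-chloropyridin-4-yl on a shared core

This account rests on a few compounds, and the source may have more. Where it says the series, first, only, none or still open, it means among the compounds named here.

Measured in a functional assay on MDA-MB-436 cells (Homo sapiens) for antiproliferative activity, read by MTT assay, with a stated time of 48 h; on this read-out higher numbers stand for weaker inhibition and lower numbers for stronger inhibition:
- compound 1 `C=CS(=O)(=O)N1CCN(c2ncnc3sc(-c4ccccc4)cc23)CC1`: 21100 nM
- compound 2 `C=CS(=O)(=O)N1CCN(c2ncnc3sc(-c4cccc5ncccc45)cc23)CC1`: 25900 nM

Compound 2 stands level with compound 1 in this assay, as their two numbers lie within the scatter of each other. Compound 3 `C=CS(=O)(=O)N1CCN(c2ncnc3sc(-c4ccnc(Cl)c4)cc23)CC1` has not yet been measured. It keeps the shared core and differs from compound 2 in one group, with 2-chloropyridin-4-yl in place of quinolin-5-yl on an aromatic carbon, next to the ring sulfur (2-chloropyridin-4-yl in place of quinolin-5-yl on an aromatic carbon).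

For the measured compounds named here, only one measured step bears on this change: a 1.2-fold higher number from compound 1 to compound 2 (0.09 log units; within the scatter), with quinolin-5-yl in place of phenyl at the same place. Going by the values given here, no measured compound carries the 2-chloropyridin-4-yl group, so the evidence is indirect and thin. The expectation rests on compound 1 at 21100 nM and compound 2 at 25900 nM, and no shift beyond the scatter is foreseen. The expected step is a 1.2-fold lower number from compound 2 to compound 3 (0.07 log units; within the scatter). For compound 3 the estimated value is 22000 nM, with an expected range from 9000 nM to 50000 nM.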

Compound 3, half-maximal inhibitory concentration: 30100 nM
Compound 3: middle estimate off by 1.4-fold (0.14 log units), on the low side, and the stated range covers the measured number.
By their numbers in this assay, from the lowest: compounds 1, 2 and 3 (each within the scatter of the next).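

At this aromatic carbon next to the ring sulfur, the read-out in this assay records a 1.2-fold higher number from compound 2 to compound 3 (0.07 log units; within the scatter) when 2-chloropyridin-4-yl takes the place of quinolin-5-yl, and a 1.4-fold higher number from compound 1 to compound 3 (0.15 log units; within the scatter) when it takes the place of phenyl. The earlier pair had shown only that a second fused ring left the number within the scatter; now a single ring carrying a ring nitrogen and a chlorine, with fewer heavy atoms than quinolin-5-yl, also stays within the scatter of both, so all three groups stand level at this position in this assay. Nothing available accounts for this closeness of the three numbers.

The compounds shown leave open whether any other group at this carbon would move the number beyond the scatter, such as a ring bearing an amine or a carboxylic acid, or a longer chain in place of the ring. Since all three share everything else, they also leave open whether this level picture would hold if another part of the shared core were changed.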